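Series notes: ester of compound 2 in hepatocyte stability

The source may hold more compounds than are shown below. What is called first, only, known or untested is meant among the compounds shown, and "the series" means these compounds.

Compound 2 `O=c1cc(N2CCN(CC3CCC(O)CC3)CC2)sc2c([N+](=O)[O-])cc(C(F)(F)F)cc12` is the lower of the two measured compounds in an ADME assay on cells (Hepatocyte, Mus musculus) for metabolic stability, with a stated time of 30 min; on this read-out higher numbers stand for a more stable compound and lower numbers for a less stable compound: compound 2 gives 51.2%, while compound 1 `CS(=O)(=O)NC1CCC(CN2CCN(c3cc(=O)c4cc(C(F)(F)F)cc([N+](=O)[O-])c4s3)CC2)CC1` gives 111%. Going by the values given here, the one measured step, a number 59.8 percentage points lower from compound 1 to compound 2 (beyond the scatter), separates these two. Compound 3 `COc1ccc(C(=O)OC2CCC(CN3CCN(c4cc(=O)c5cc(C(F)(F)F)cc([N+](=O)[O-])c5s4)CC3)CC2)cc1` differs from compound 2 by (4-methoxyphenyl)carbonyl in place of hydrogen on an oxygen on a saturated carbon. Among the compounds with values here, no measured step bears directly on this change: the step from compound 1 to compound 2 exchanges one group on the saturated ring for another, whereas here a group is added onto the oxygen of the hydroxy, and nothing among the measured compounds shows what such an addition does in this assay. The expectation for compound 3 therefore stays near compound 2, with a wide range and a slight lean downward, as a step of a number 11.2 percentage points lower from compound 2 to compound 3 (beyond the scatter). Compound 3 is estimated at 40%, within 10% to 75%.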

Compound 3, percent of the compound remaining: 31%
For compound 3 the middle estimate is 9 percentage points above the measured one; the range from low to high includes it.
By their numbers in this assay, from the lowest: compound 3; then compound 2; then compound 1.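

In this assay the step of a number 20.2 percentage points lower from compound 2 to compound 3 (beyond the scatter) shows that the hydroxy oxygen on the saturated carbon tolerates no free addition: (4-methoxyphenyl)carbonyl placed there moves the read-out down, which compound 1 and compound 2 alone could not show. On the saturated ring carbon, the exchange of methanesulfonamido for ((4-methoxyphenyl)carbonyl)oxy gives a number 80 percentage points lower from compound 1 to compound 3 (beyond the scatter) and so spans a wider range than the hydroxy change did, with methanesulfonamido highest of the three groups and the ester lowest. No evidence at hand bears on what lies behind these falls.

The compounds shown leave open whether the fall belongs to the ester link or to the 4-methoxyphenyl ring, which an acetyl ester or a methyl ether on the same oxygen would separate. They also leave open how an amine or a carboxylic acid on that saturated ring carbon would stand against methanesulfonamido.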